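Phenyl to Butyl on the Shared Core: Cytotoxicity Expected

The compounds below may be only part of what the source reports. "The series", "measured", "known", "first", "only" and "open" are said of these compounds alone.

Measured compounds:
compound 1 `COc1cccc(-c2nc3c(-c4ccco4)n[nH]c3c(=O)n2NC(=O)c2cccnc2)c1`: 12.8%
compound 2 `O=C(Nn1c(-c2ccccc2)nc2c(-c3ccc(Cl)cc3)n[nH]c2c1=O)c1ccccc1`: 92%

In a functional assay on HT-29 cells (Homo sapiens) for cytotoxicity, read by sulforhodamine B assay, with a stated time of 2 days, tested at 100 uM (a higher number here means more inhibition at the concentration tested (going by the name of the read-out), a lower number less inhibition), compound 2 gives 92%, the highest of the two numbers shown. The nearest is compound 1, which in this assay gives 12.8%, a gap beyond the scatter; the two compounds differ in more than one place, so their values alone are what is known.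

Compound 3 `CCCCc1nc2c(-c3ccc(Cl)cc3)n[nH]c2c(=O)n1NC(=O)c1ccccc1` is the unmeasured partner of compound 2. It differs from it by butyl in place of phenyl on an aromatic carbon, the place being an aromatic carbon between two ring nitrogen atoms of the shared core, ortho to a benzamido group. Among the measured compounds shown here, no step of this kind between measured compounds exists to lean on, so the expectation rests on compound 2 alone. A loss beyond the scatter is expected, the step from compound 2 to compound 3 estimated as a number 30 percentage points lower from compound 2 to compound 3 (beyond the scatter). Compound 3 is therefore expected to give 62% in this assay, with a range from 25% to 92%.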

Compound 3, a percentage reported as inhibition, at one concentration (the size of the read-out at that concentration, not a potency): 89.5%
Compound 3: the middle estimate sits 27.5 percentage points below what was measured; low and high end bracket the measured number.
By their numbers in this assay, from the lowest: compound 1; then compounds 3 and 2 (each within the scatter of the next).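

In this assay, butyl in place of phenyl on the aromatic carbon between two ring nitrogen atoms of the shared core gives a number 2.5 percentage points lower from compound 2 to compound 3 (within the scatter), the first step read at this position. With the benzamido group and the rest of the shared core held fixed, a six-membered aromatic ring and an open butyl chain at this carbon therefore cannot be told apart at the concentration tested. Nothing available accounts for this result.

On these data alone, whether this position accepts groups of other kinds stays open, for instance a methyl group, a longer chain such as octyl, an amine or a carboxylic acid. Also open, as far as these compounds go, is whether butyl and phenyl would read alike on a core carrying other groups elsewhere, such as furan-2-yl in place of the 4-chlorophenyl group.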